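Pyridin-2-yl in Place of a Phenoxyethyl Chain: Compound 4

The source may report more compounds than this note shows. Statements on the series, on what has been measured and on what is new or still open speak of the compounds shown alone.

Compound 2 `Nc1nc(N2CCN(C(=O)COc3ccc(Cl)cc3)CC2)c2nc(CCOc3ccc(F)cc3)sc2n1` gives 3540 nM in a functional assay on cells (Lymphocyte, Homo sapiens) (a lower number here means a stronger inhibitor, a higher number a weaker inhibitor), the highest of the two numbers measured. Compound 3 `Nc1nc(N2CCN(C(=O)COc3ccc(F)cc3)CC2)c2nc(-c3ccc(F)cc3)sc2n1` gives 70 nM in this assay. Compound 1 `CCCCCN1CCN(c2nc(N)nc3sc(-c4ccc(F)cc4)nc23)CC1` gives > 10000 nM in this assay, which is a limit and not a number, (the limit of > 10000 nM in this assay, at which 1 of the 3 values shown sits). Going by the values given here, the one measured single-place step, an at least 140-fold lower number from compound 1 to compound 3 (2.15 log units; beyond the scatter), concerns the amine nitrogen in the ring, not the carbon changed here. Compound 4 `Nc1nc(N2CCN(C(=O)COc3ccc(Cl)cc3)CC2)c2nc(-c3ccccn3)sc2n1` differs from compound 2 by pyridin-2-yl in place of 2-(4-fluorophenoxy)ethyl on an aromatic carbon. Compounds 2 and 3 differ in two places, one of them this carbon, and compound 3, which carries a six-membered aromatic ring there, gives the lower number. Among the compounds with values here, no directly comparable step exists, so the expectation is uncertain. Compound 4 is expected at 250 nM, within 40 nM to 1600 nM, which would be a step of a 14-fold lower number from compound 2 to compound 4 (1.15 log units; beyond the scatter).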

Compound 4, half-maximal inhibitory concentration: 230 nM
Beside the measured number, compound 4's estimate is 1.1-fold (0.04 log units) above it, and the stated range covers the measured number.
By their numbers in this assay, from the lowest: compound 3; then compound 4; then compound 2. At a limit, above all of these: compound 1.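

Pyridin-2-yl in place of 2-(4-fluorophenoxy)ethyl gives a 15-fold lower number from compound 2 to compound 4 (1.19 log units; beyond the scatter), the only single-place step shown at this aromatic carbon, so this position clearly affects the read-out in this assay. The step cannot separate the loss of the chain from the entry of the ring nitrogen. Nothing given here accounts for its size. Still open, on these data alone, is how a plain phenyl, a pyridin-3-yl or a shorter chain ending in an amine would compare at this carbon with the rest of compound 4 unchanged.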